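A few compounds are considered here, and "the series" means these few. Any claim that something is new, unique, unknown or untested is made for them only; others in the source may bear on it.

Of the compounds shown here, two have been measured in a functional assay on HCT-116 cells (Homo sapiens) for cytotoxicity, read by MTT assay, with a stated time of 48 h; a lower number here means a stronger inhibitor, a higher number a weaker inhibitor. Compound 1 `CC(C)COc1ccc2c(Cl)ccnc2c1` gives 2490 nM in this assay. Compound 2 `CN(C)CCNc1ccnc2cc(OCc3ccccc3)ccc12` gives 1980 nM in this assay, the lower of the two numbers, though the gap between compound 2 and compound 1 lies within the usual scatter of repeated measurements, so the two cannot be told apart on these numbers.

The step to be considered leads from compound 2 to compound 3 `Clc1ccnc2cc(OCc3ccccc3)ccc12`, which has not yet been measured in this assay. The change is chloro in place of (2-(dimethylamino)ethyl)amino on an aromatic carbon: a chloro in place of (2-(dimethylamino)ethyl)amino on an aromatic carbon, the same kind of group that compound 1 carries, while the benzyloxy part of compound 2 remains.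

Within the data shown here, no directly comparable step between measured compounds exists, so the expected direction rests on the two numbers alone. With compound 1 at 2490 nM as the nearest guide, no change beyond the scatter is expected. Compound 3 is therefore estimated at 2800 nM, with a range from 1200 nM to 6500 nM, which would mean an expected step of a 1.4-fold higher number from compound 2 to compound 3 (0.15 log units; within the scatter).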

Compound 3, half-maximal inhibitory concentration: 2470 nM
The estimate for compound 3 lay 1.1-fold (0.05 log units) above the measured number; the range from low to high includes it.
By their numbers in this assay, from the lowest: compounds 2, 3 and 1 (each within the scatter of the next).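

In this assay, a chloro in place of (2-(dimethylamino)ethyl)amino on the aromatic carbon opposite the ring nitrogen gives a 1.2-fold higher number from compound 2 to compound 3 (0.10 log units; within the scatter), so compounds 2 and 3 cannot be told apart, even though the group that leaves has 6 heavy atoms and the one that enters has 1. With chloro at that place in both compounds, phenyl in place of isopropyl on a saturated chain carbon bound to an oxygen on an aromatic ring gives a 1.0-fold lower number from compound 1 to compound 3 (0.00 log units; within the scatter), so this second change also leaves no readable difference. No further data bear on why neither change can be read in these numbers.

From the compounds shown here alone, only chloro and (2-(dimethylamino)ethyl)amino can be compared at the place opposite the ring nitrogen, so it remains open whether a plain amine, a morpholine or a longer amine chain there would give a number beyond the scatter. On the oxygen side, the compounds cover only the phenyl and isopropyl versions, which leaves open how a carboxylic acid or a pyridine ring at the end of that chain would read.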